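This account rests on a few compounds, and the source may have more. Where it says the series, first, only, none or still open, it means among the compounds named here.

In a functional assay, with a stated time of 6 min (on this read-out higher numbers stand for weaker inhibition and lower numbers for stronger inhibition), compound 1 `S=c1oc(-c2ccc3c(c2)OCCO3)nn1CNc1ccccc1` gives 5140 nM, compound 2 `Fc1cccc(NCn2nc(-c3ccc4c(c3)OCCO4)oc2=S)c1` gives 6620 nM and compound 3 `S=c1oc(-c2ccc3c(c2)OCCO3)nn1CNc1ccccc1Cl` gives 7230 nM. Compound 3 thus stands level with the other two, since the readings show a 1.4-fold higher number from compound 1 to compound 3 (0.15 log units; within the scatter) and a 1.1-fold higher number from compound 2 to compound 3 (0.04 log units; within the scatter). The next compound, compound 4 `S=c1oc(-c2ccc3c(c2)OCCO3)nn1CNc1ccc(Cl)cc1`, has not yet been measured. It carries 4-chlorophenyl in place of 2-chlorophenyl on an amine nitrogen. Within the data shown here, no measured compound has this 4-chlorophenyl group, so the evidence is indirect. The readings already show a 1.4-fold higher number from compound 1 to compound 3 (0.15 log units; within the scatter), and fluoro in place of hydrogen on an aromatic carbon shows a 1.3-fold higher number from compound 1 to compound 2 (0.11 log units; within the scatter). The exchange of 3-fluorophenyl for 2-chlorophenyl is likewise small. Every step among these compounds stays within the scatter, so no change beyond the scatter is expected in this assay, and no direction can be assigned with confidence. The expected step is a 1.2-fold lower number from compound 3 to compound 4 (0.08 log units; within the scatter). The estimate for compound 4 is 6000 nM, with an expected range from 3000 nM to 12000 nM.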

Compound 4, half-maximal inhibitory concentration: 7270 nM
For compound 4 the middle estimate is 1.2-fold (0.08 log units) below the measured one, and the stated range covers the measured number.
By their numbers in this assay, from the lowest: compounds 1, 2, 3 and 4 (each within the scatter of the next).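

In this assay, 4-chlorophenyl in place of 2-chlorophenyl on the amine nitrogen gives a 1.0-fold higher number from compound 3 to compound 4 (0.00 log units; within the scatter) and so adds a second placing of the chloro that cannot be told apart from the first. The 4-chlorophenyl compound also stays within the scatter of the other two, with a 1.1-fold higher number from compound 2 to compound 4 (0.04 log units; within the scatter) and, for chloro in place of hydrogen on an aromatic carbon, a 1.4-fold higher number from compound 1 to compound 4 (0.15 log units; within the scatter), so all four groups on this nitrogen read alike. Nothing available here offers an explanation for this flat reading.

The groups shown on this nitrogen are phenyl rings bearing a single halogen or none, so it remains open whether a methoxy group, a carboxylic acid or an amine on the ring, or a saturated cyclohexyl group in its place, would move the number beyond the scatter. Equally open, as far as these compounds go, is whether any change to the shared core would do so.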